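The source may hold more compounds than are shown below. What is called first, only, known or untested is meant among the compounds shown, and "the series" means these compounds.

Within the data shown here, compound 1 `C[C@]1(C(=O)N2CC[C@](c3ccc(C(F)(C(F)(F)F)C(F)(F)F)cc3)(S(=O)(=O)c3ccc(F)cc3)C2)CC[C@H](C(=O)O)CC1` is the only member of this small set with a recorded number: in an ADME assay on microsomes from liver (Mus musculus) for metabolic stability, with a stated time of 10 min (a lower number here means that less of the compound is left, a higher number that more of the compound is left), compound 1 gives 95%. Compound 2 `COC(=O)[C@H]1CC[C@H](C(=O)N2CC[C@](c3ccc(C(F)(C(F)(F)F)C(F)(F)F)cc3)(S(=O)(=O)c3ccc(F)cc3)C2)CC1` belongs to the same family, but in this assay compound 2 gives "not determined" (no result reported). Compound 3 `O=C(N1CC[C@](c2ccc(C(F)(C(F)(F)F)C(F)(F)F)cc2)(S(=O)(=O)c2ccc(F)cc2)C1)C1(F)CCS(=O)(=O)CC1` has not yet been measured. It differs from compound 1 in one place: 4-fluoro-1,1-dioxothian-4-yl in place of 4-carboxy-1-methylcyclohexyl on a carbonyl carbon. Among the measured compounds shown here, no measured pair in this set shares that change, so there is no measured step to lean on. Because compound 1 already stands at 95%, there is little room for a rise. A modest fall is expected for compound 3, estimated as a number 10 percentage points lower from compound 1 to compound 3 (within the scatter). Compound 3 is therefore estimated to give 85% in this assay, with an expected range from 60% to 98%.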

Compound 3, percent of the compound remaining: 90%
Compound 3: middle estimate off by 5 percentage points, on the low side; the range from low to high includes it.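

With 4-fluoro-1,1-dioxothian-4-yl in place of 4-carboxy-1-methylcyclohexyl on the carbonyl carbon, this assay shows a number 5 percentage points lower from compound 1 to compound 3 (within the scatter), so the two groups cannot be told apart in this read-out. The high reading of compound 1 therefore does not depend on its carboxylic acid or its hydrogen-bond donor, as compound 3 has neither and still gives a high reading. Nothing measured here explains why the reading holds.

Among these compounds, this single pair cannot separate the part played by the fluorine from that of the sulfur-containing ring, and no step involving compound 2 can be read. On these data alone, how an amine or a longer chain on the carbonyl carbon would fare also remains open.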